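This account rests on a few compounds, and the source may have more. Where it says the series, first, only, none or still open, it means among the compounds named here.

Compound 1 `CC1CCN(Cc2ccc3nc(NC(=O)N/N=C/c4cn(Cc5ccc(Cl)cc5Cl)c5ccccc45)sc3c2)CC1`: 3640 nM
Compound 2 `CCN(CC)Cc1ccc2nc(NC(=O)N/N=C/c3c[nH]c4ccccc34)sc2c1`: 3300 nM
Compound 3 `CC1CCN(Cc2ccc3nc(NC(=O)N/N=C/c4cn(Cc5ccccc5Cl)c5ccccc45)sc3c2)CC1`: 3330 nM

In a functional assay on A549 cells (Homo sapiens) for cytotoxicity, read by MTT assay, with a stated time of 72 h (a lower number here means a stronger inhibitor, a higher number a weaker inhibitor), compound 2 gives 3300 nM, and it stands alongside compounds 3 and 1: all three numbers lie within the usual scatter of one another, so none can be set apart as stronger or weaker.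

Compound 4 `CCN(CC)Cc1ccc2nc(NC(=O)N/N=C/c3cn(Cc4ccc(C)cc4)c4ccccc34)sc2c1` has not yet been measured. It differs from compound 2 in one place: 4-methylbenzyl in place of hydrogen on an aromatic nitrogen. Among the measured compounds shown here, no measured pair differs by exactly this change. For the measured compounds named here, the one measured step, a 1.1-fold lower number from compound 1 to compound 3 (0.04 log units; within the scatter), concerns a chloro on the benzyl group carried on the same aromatic nitrogen, and it shows that altering that benzyl group leaves this assay unchanged within the scatter. Beyond that, compound 1, which carries a substituted benzyl on that nitrogen, gives 3640 nM, and compound 3, which carries a substituted benzyl there as well, gives 3330 nM; both numbers are indistinguishable from the value of compound 2, which carries hydrogen there, though these pairs also differ elsewhere in the molecule.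

On this basis the expected step from compound 2 to compound 4 is no change at the digits printed from compound 2 to compound 4 (within the scatter), that is, no movement beyond the scatter in either direction. Compound 4 is therefore estimated at 3300 nM in this assay, with a range from 1500 nM to 7500 nM.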

Compound 4, half-maximal inhibitory concentration: 1510 nM
The estimate for compound 4 lay 2.2-fold (0.34 log units) above the measured number; measured number inside the range.
By their numbers in this assay, from the lowest: compound 4; then compounds 2, 3 and 1 (each within the scatter of the next).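

In this assay, the aromatic nitrogen of the five-membered ring now proves able to shift the number: with 4-methylbenzyl in place of hydrogen, there is a 2.2-fold lower number from compound 2 to compound 4 (0.34 log units; beyond the scatter). This is the first pair to differ only by putting a group on that nitrogen where hydrogen stood, and its step is the only one shown that lies beyond the scatter, whereas the earlier step, a 1.1-fold lower number from compound 1 to compound 3 (0.04 log units; within the scatter), only changed a chloro on a benzyl group already present and left the assay unchanged. No measurement is available to account for this modest step.

Going by these compounds, it remains open whether the step belongs to benzyl groups on this nitrogen in general or to the 4-methylbenzyl group in particular, as compound 1 and compound 3 also differ from compound 2 elsewhere in the molecule and so give no clean comparison. Also unanswered is how a plain methyl, an unsubstituted benzyl or a chain ending in a carboxylic acid would read at the same nitrogen on the core of compound 2.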